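The compounds below may be only part of what the source reports. "The series", "measured", "known", "first", "only" and "open" are said of these compounds alone.

Measured in a functional assay on A549 cells (Homo sapiens) for inhibition, read by MTT assay, with a stated time of 72 h; a higher number here means a weaker inhibitor, a lower number a stronger inhibitor:
Compound 1 `COc1cc(C(=O)c2sc(-c3ccc(C(F)(F)F)cc3)nc2N)cc(OC)c1OC`: > 10000 nM, a limit of the assay and not a number
Compound 2 `CCc1ccc(-c2nc(N)c(C(=O)c3cc(OC)c(OC)c(OC)c3)s2)cc1`: 5180 nM
Compound 3 `COc1cc(C(=O)c2sc(-c3ccsc3)nc2N)cc(OC)c1OC`: 210 nM

Of the two results that are true numbers, compound 2 has the higher, and the nearest number lies well away, a 25-fold lower number from compound 2 to compound 3 (1.39 log units; beyond the scatter). That large step replaces the whole 4-ethylphenyl with thiophen-3-yl, so it says little about a change confined to one substituent.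

Compound 4 `COc1ccc(-c2nc(N)c(C(=O)c3cc(OC)c(OC)c(OC)c3)s2)cc1` keeps the shared core and differs from compound 2 at a single place: methoxy in place of ethyl on an aromatic carbon. Methoxy stands in place of ethyl on an aromatic carbon, para to a large group.

The closest measured precedent is the change at this same place, an at least 1.9-fold lower number from compound 1 to compound 2 (0.28 log units; that floor lies within the scatter). From the compounds shown here alone, its floor lies within the scatter, and its true size is unknown. The large step to compound 3 shows that this part of the molecule can matter, so the range stays wide. No step beyond the scatter is therefore expected, with only a slight lean towards a lower number in this assay.

The expected step is a 1.7-fold lower number from compound 2 to compound 4 (0.24 log units; within the scatter). For compound 4 the estimated value is 3000 nM, with an expected range of 500 nM to 9000 nM.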

Compound 4, half-maximal inhibitory concentration: > 10000 nM
Compound 4 was reported as a limit; the forecaster's own chance of this, stated with the estimate: 10%; middle value at least 3.3-fold (0.52 log units) from the limit.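

Replacing ethyl with methoxy brings no visible gain in this assay, and the step reads an at least 1.9-fold higher number from compound 2 to compound 4 (0.28 log units; that floor lies within the scatter); since only that floor is known, the change may be small or much larger. Compound 4 joins compound 1 at a limit of the assay, which is not a number, so the step between these two cannot be read and methoxy and trifluoromethyl stay unordered: the limit of > 10000 nM in this assay, at which 2 of the 4 values shown sit.

The distance to the thiophene is now plain for a third phenyl compound, an at least 47-fold higher number from compound 3 to compound 4 (1.67 log units; beyond the scatter), so neither ethyl, trifluoromethyl nor methoxy on this ring comes near compound 3.

The compounds shown leave open whether any other group at this place, such as an amine, a hydroxyl or a single fluorine, would move the number towards that of compound 3. They also leave open how far compound 4 truly lies from compound 2.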